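A few compounds are considered here, and "the series" means these few. Any claim that something is new, unique, unknown or untested is made for them only; others in the source may bear on it.

In a functional assay on NCI-H226 cells (Homo sapiens) for inhibition, read by MTT assay, with a stated time of 48 h, tested at 10 uM (a higher number here means more inhibition at the concentration tested (going by the name of the read-out), a lower number less inhibition), compound 3 `COc1cc(NC(=O)Nc2cc(Nc3cc(C(F)(F)F)ccc3OC)ncn2)cc(OC)c1` gives 60%, the highest of the three numbers shown: compound 1 `COc1cc(NC(=O)Nc2cc(Nc3ccc(C)c(F)c3)ncn2)cc(OC)c1` gives 39.7% and compound 2 `COc1cc(NC(=O)Nc2cc(Nc3cc(F)ccc3OC)ncn2)cc(OC)c1` gives 37.7%, each beyond the scatter below compound 3. Compound 4 `COc1ccc(C(F)(F)F)cc1Nc1cc(NC(=O)Nc2c(Cl)cccc2Cl)ncn1` differs from compound 3 by 2,6-dichlorophenyl in place of 3,5-dimethoxyphenyl on an amide-type nitrogen. Neither measured step bears directly on this change: a number 2 percentage points lower from compound 1 to compound 2 (within the scatter) and a number 22.3 percentage points higher from compound 2 to compound 3 (beyond the scatter) both concern the aryl group on the nitrogen on the aromatic ring, not the amide-type nitrogen. Going by the values given here, the data thus offer no precedent for the size or direction of the step in this assay, so the expectation is wide and centred near compound 3. Compound 4 is estimated at 50%, within 25% to 75%, an expected step of a number 10 percentage points lower from compound 3 to compound 4 (within the scatter).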

Compound 4, a percentage reported as inhibition, at one concentration (the size of the read-out at that concentration, not a potency): 60.1%
Compound 4: middle estimate off by 10.1 percentage points, on the low side, within the range that was stated.
By their numbers in this assay, from the lowest: compounds 2 and 1 (each within the scatter of the next); then compounds 3 and 4 (each within the scatter of the next).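

At the amide-type nitrogen, 2,6-dichlorophenyl in place of 3,5-dimethoxyphenyl gives a number 0.1 percentage points higher from compound 3 to compound 4 (within the scatter) in this assay, the first reading at this position among the compounds shown. For this pair, the read-out therefore holds with both methoxy groups gone and chlorine in their place. No experimental evidence is available to explain why the read-out holds across this change. On these data alone, whether a cyclohexyl group or a chain bearing an amine on this nitrogen would hold it too remains open. So does whether 2,6-dichlorophenyl would give the same read-out alongside the aryl groups of compound 1 and compound 2.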